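The compounds below may be only part of what the source reports. "The series", "measured", "known", "first", "only" and "open" are said of these compounds alone.

Measured so far:

- compound 1, `COc1ccc(Cn2nncc2-c2cc(OC)c(OC)c(OC)c2)cc1`: 8660 nM
- compound 2, `COc1ccc(Cn2nncc2-c2cc(OC)c(OC)c(OC)c2)cc1Br`: in this test compound 2 gives only a limit, > 10000 nM
- compound 3, `COc1ccc(-c2cnnn2Cc2cc(OC)c(OC)c(OC)c2)cc1`: 5560 nM

All three were tested in a functional assay on K562 cells (Homo sapiens) for cytotoxicity, read by MTT assay, with a stated time of 5 days; a higher number here means a weaker inhibitor, a lower number a stronger inhibitor. Compound 1 and compound 2 share one core and differ in a single spot: bromo in place of hydrogen on an aromatic carbon. That change gave an at least 1.1-fold higher number from compound 1 to compound 2 (0.06 log units; that floor lies within the scatter). Since compound 2 reached the ceiling of the test, (the limit of > 10000 nM in this assay, at which 1 of the 3 values shown sits), the true size of this step is not known; it is at least as large as stated and may be larger.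

Compound 3 is built from the same atoms as compound 1, joined in a different way; the difference between the two cores is not broken down here. Its value and that of compound 1 lie within the usual scatter of each other, so no order can be read between them.

Compound 4, `COc1ccc(-c2cnnn2Cc2cc(OC)c(OC)c(OC)c2)cc1Br`, is not yet measured. It relates to compound 3 exactly as compound 2 relates to compound 1: bromo in place of hydrogen on an aromatic carbon. The surroundings of the change read the same for both pairs, so it is the same change on a differently joined core.

Among the compounds with values here, for compound 4 the expected step is a 1.7-fold higher number from compound 3 to compound 4 (0.23 log units; within the scatter), which rests on the only measured example, the step from compound 1 to compound 2, where bromo in place of hydrogen pushed the value to the limit. Compound 4 is therefore estimated at 9500 nM, with a likely range from 4000 nM to 25000 nM, and a real chance that this assay again returns only a limit.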

Compound 4, half-maximal inhibitory concentration: > 10000 nM
Compound 4: a limit, no number (the forecaster's own chance of this, stated with the estimate: 40%); middle value at least 1.0-fold (0.02 log units) away from the limit.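

In this assay compound 4 gives only a limit, > 10000 nM. Bromo in place of hydrogen on the differently joined core gave an at least 1.7-fold higher number from compound 3 to compound 4 (0.25 log units; that floor lies within the scatter), and since compound 2 also gave a limit, the two steps can be set side by side only as floors: the same change on two cores in this assay, an at least 1.1-fold higher number (0.06 log units; that floor lies within the scatter) from compound 1 to compound 2 and an at least 1.7-fold higher number (0.25 log units; that floor lies within the scatter) from compound 3 to compound 4; the limit leaves it open whether they differ This shows that on both cores the compound carrying the bromo returned no number, but it does not show how large the step truly is, whether it matches from one core to the other, or even that it exceeds the usual scatter, as both floors lie within it: the limit of > 10000 nM in this assay, at which 2 of the 4 values shown sit.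

The compounds shown leave open whether another group in place of the bromo, such as chloro, an amine or a carboxylic acid, would give a measured number on either core. They also leave open the true size of the bromo step, which only a reading past the limit for the 3-bromo-4-methoxyphenyl compounds could settle.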